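This account rests on a few compounds, and the source may have more. Where it says the series, first, only, none or still open, it means among the compounds named here.

In a functional assay on the whole organism (strain Wistar) for inhibition, with Rattus norvegicus as the target, read by paw edema, with stated times of 30 min and 3 h, at a dose of 100 mg/kg by the oral route (on this read-out higher numbers stand for more inhibition at the one dose given (going by the name of the read-out) and lower numbers for less inhibition), compound 1 `COc1cc(C(N)=O)nn1-c1ccccc1` gives 34.3%, compound 2 `CNC(=O)c1cc(OC)n(-c2ccccc2)n1` gives 57.9% and compound 3 `CCCCOc1cc(C(N)=O)nn1-c1ccccc1` gives 26.5%. Among these three, compound 3 carries the lowest number; its gap to compound 1 is within the scatter, while its gap to compound 2 lies beyond it. Compound 4 `CCCCOc1cc(C(=O)NC)nn1-c1ccccc1` is the unmeasured counterpart of compound 3, differing by methyl in place of hydrogen on an amide-type nitrogen. The same change has been measured once in the series: a number 23.6 percentage points higher from compound 1 to compound 2 (beyond the scatter). The other measured step, a number 7.8 percentage points lower from compound 1 to compound 3 (within the scatter), concerns a different change and offers no guide here. An increase of comparable size is therefore expected in this assay, and compound 4 is estimated at 50%, between 35% and 65%, an expected step of a number 23.5 percentage points higher from compound 3 to compound 4 (beyond the scatter).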

Compound 4, a percentage reported as inhibition, in the whole organism at one dose (the size of the read-out at that dose, not a potency): 65%
The estimate for compound 4 lay 15 percentage points below the measured number; the measured number falls inside the stated range.
By their numbers in this assay, from the lowest: compounds 3 and 1 (each within the scatter of the next); then compounds 2 and 4 (each within the scatter of the next).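

Methyl on the amide-type nitrogen also raises the number on the butoxy-bearing core in this assay, with a number 38.5 percentage points higher from compound 3 to compound 4 (beyond the scatter), so the rise is not confined to the core of compound 1, though its size differs between the cores: the same change on two cores in this assay, a number 23.6 percentage points higher (beyond the scatter) from compound 1 to compound 2 and a number 38.5 percentage points higher (beyond the scatter) from compound 3 to compound 4, 14.9 percentage points apart, beyond the scatter of two such steps.
The propyl change, with the methylamide in place, gives a number 7.1 percentage points higher from compound 2 to compound 4 (within the scatter), and neither of its two steps leaves the scatter, though the two differ from each other: the same change on two cores in this assay, a number 7.8 percentage points lower (within the scatter) from compound 1 to compound 3 and a number 7.1 percentage points higher (within the scatter) from compound 2 to compound 4, 14.9 percentage points apart, beyond the scatter of two such steps.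
Open, going by these compounds, is whether an ethyl group or a longer chain on the amide nitrogen, or a second methyl there, keeps this rise. Also open, on these data alone, is how a carboxylic acid in place of the amide would read.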